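This account rests on a few compounds, and the source may have more. Where it says the series, first, only, none or still open, it means among the compounds named here.

Measured so far in a functional assay on SW480 cells (Homo sapiens) for cytotoxicity, read by MTT assay, with a stated time of 4 days; on this read-out lower numbers stand for stronger inhibition and higher numbers for weaker inhibition:
compound 1 `C=C1C[C@]23C[C@@]1(O)CC[C@H]2c1ccc(O)c(C)c1[C@@H]3Cn1cc(-c2ccccn2)nn1` gives > 20000 nM, a limit of the assay.
compound 2 `C=C1C[C@]23C[C@@]1(O)CC[C@H]2c1cc(Br)c(O)c(C)c1[C@@H]3Cn1cc(-c2ccc(OC)cc2)nn1` gives > 20000 nM, a limit of the assay.
compound 3 `C=C1C[C@]23C[C@@]1(O)CC[C@H]2c1cc(Br)c(O)c(C)c1[C@@H]3Cn1cc(-c2ccccc2)nn1` gives > 20000 nM, a limit of the assay.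

The three compounds share one core and differ only in the aromatic group attached to the five-membered ring with three nitrogens and in whether a bromine sits on the phenol-bearing ring. No measured number exists for any of them: each value is the limit of > 20000 nM in this assay, at which 3 of the 3 values shown sit. Compound 3 therefore has no definite place among the measured compounds; its potency is bounded only by that limit.

Going by the values given here, the single step between two measured compounds that differ in one place is a step that the two limits leave unreadable from compound 2 to compound 3. Both ends of that step are limits, so its size cannot be read.

Compound 4 `C=C1C[C@]23C[C@@]1(O)CC[C@H]2c1cc(Br)c(O)c(C)c1[C@@H]3Cn1cc(-c2ccccn2)nn1` differs from compound 3 by pyridin-2-yl in place of phenyl on an aromatic carbon. Compound 1 carries the same pyridin-2-yl group without the bromine and also sits at the limit. Among the compounds with values here, no measured step gives a readable size for this kind of change, so there is no ground to expect a number inside the measurable range. Compound 4 is expected to give 30000 nM in this assay, with a range from 10000 nM to 100000 nM, most likely reported again as a limit. The step expected from compound 3 to compound 4 is a step that the limit leaves unreadable from compound 3 to compound 4, no change beyond the scatter.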

Compound 4, half-maximal inhibitory concentration: > 20000 nM
Compound 4 ended at the assay's limit; the forecaster's own chance of this, stated with the estimate: 85%; the middle value does not contradict the limit.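

No step can be read from compound 1, compound 2 or compound 3 to compound 4, because both ends of each step are limits and not numbers: the limit of > 20000 nM in this assay, at which 4 of the 4 values shown sit.

The compounds shown leave open whether the bromine or the choice of pyridin-2-yl, phenyl or 4-methoxyphenyl changes potency at all in this assay.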